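Bromo to hydroxymethyl: expected maximal response for compound 4

The source may report more compounds than this note shows. Statements on the series, on what has been measured and on what is new or still open speak of the compounds shown alone.

Measured so far, largest response in this assay:
compound 1 `COc1ccc2c(c1)OC(COc1ccc(CCC(=O)O)c(F)c1)CC2`: 58%
compound 2 `O=C(O)CC(c1ccc(F)cc1)c1ccc(OCC2COc3ccc(Cl)cc3O2)cc1`: 83%
compound 3 `CC#C[C@@H](CC(=O)O)c1ccc(OC[C@H]2COc3ccc(Br)cc3O2)cc1`: 69%

In a functional assay on HEK293 cells for agonist activity at Free fatty acid receptor 1 (Homo sapiens), read by fluorescence and calcium flux, with a stated time of 10 min (on this read-out higher numbers stand for larger maximal responses and lower numbers for smaller maximal responses), compound 3 stands second highest of the three numbers; compound 1 is lower and compound 2 higher, both gaps beyond the scatter. Among the compounds with values here, the three measured compounds differ from one another at several places at once, so no single-change step is available. Compound 4 `CC#C[C@@H](CC(=O)O)c1ccc(OC[C@H]2COc3ccc(CO)cc3O2)cc1` differs from compound 3 in one place: hydroxymethyl in place of bromo on an aromatic carbon. For this change a small downward step is expected in this assay, possibly within the scatter. The step expected is a number 7 percentage points lower from compound 3 to compound 4 (within the scatter). Compound 4 is therefore estimated at 62%, with a range of 45% to 80%.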

Compound 4, largest response reached (Emax), in percent of the reference or control that the assay uses: 42%
For compound 4 the middle estimate is 20 percentage points above the measured one, and the stated range ends above it.
By their numbers in this assay, from the lowest: compound 4; then compound 1; then compound 3; then compound 2.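

In this assay, within the data shown here, hydroxymethyl in place of bromo on this aromatic carbon gives a number 27 percentage points lower from compound 3 to compound 4 (beyond the scatter), the first single-change reading. The maximal response therefore depends on the group at this position, and this exchange lowers it beyond the scatter. Nothing available explains the drop.

Going by these compounds, how a methyl, a methoxy, an amine or a carboxylic acid at this position would compare remains open. Also open, on these data alone, is whether the same exchange would give a similar step on the core of compound 2.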